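Compound 3 to compound 4: thiophen-2-yl for cyclopent-1-en-1-yl

This account rests on a few compounds, and the source may have more. Where it says the series, first, only, none or still open, it means among the compounds named here.

Compound 3 `Cn1nc2c(=O)n(CC3(O)CCN(Cc4ccc(C5=CCCC5)cc4Cl)CC3)cnc2c1-c1ccc(CN)cc1` stands lowest of the three measured compounds in an ADME assay on Caco-2 cells (Homo sapiens) for permeability, in the apical to basolateral direction (a lower number here means that the compound crosses the layer more slowly, a higher number that the compound crosses the layer faster), at 0.23 10^-6 cm/s. Compound 1 `Cn1nc2c(=O)n(CC3(O)CCN(Cc4ccc(-c5cnco5)cc4Cl)CC3)cnc2c1-c1ccc(CN)cc1` gives 0.86 10^-6 cm/s, and compound 2 `Cn1nc2c(=O)n(CC3(O)CCN(Cc4ccc(-c5ccco5)cc4Cl)CC3)cnc2c1-c1ccc(CNS(C)(=O)=O)cc1` gives 50 10^-6 cm/s. Compound 4 `Cn1nc2c(=O)n(CC3(O)CCN(Cc4ccc(-c5cccs5)cc4Cl)CC3)cnc2c1-c1ccc(CN)cc1` is unmeasured, and its change from compound 3 is thiophen-2-yl in place of cyclopent-1-en-1-yl on an aromatic carbon. Going by the values given here, one measured step bears on it, a 3.7-fold lower number from compound 1 to compound 3 (0.57 log units; beyond the scatter), where cyclopent-1-en-1-yl replaces 1,3-oxazol-5-yl on that same aromatic carbon. Compound 2 differs from compound 3 in more than one place and offers no direct guide. The expected change in this assay is a small rise, smaller than that step: a 2.2-fold higher number from compound 3 to compound 4 (0.34 log units; beyond the scatter). For compound 4 the estimate is 0.5 10^-6 cm/s, with an expected range of 0.17 10^-6 cm/s to 1.5 10^-6 cm/s.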

Compound 4, apparent permeability: 0.8 10^-6 cm/s
Compound 4: middle estimate off by 1.6-fold (0.20 log units), on the low side; the range from low to high includes it.
By their numbers in this assay, from the lowest: compound 3; then compounds 4 and 1 (each within the scatter of the next); then compound 2.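

At this aromatic carbon, in this assay, thiophen-2-yl in place of cyclopent-1-en-1-yl gives a 3.5-fold higher number from compound 3 to compound 4 (0.54 log units; beyond the scatter). Thiophen-2-yl in place of 1,3-oxazol-5-yl gives a 1.1-fold lower number from compound 1 to compound 4 (0.03 log units; within the scatter), so these two aromatic five-membered rings cannot be told apart here, while cyclopent-1-en-1-yl stands lower than both. Nothing shown explains either step. As far as these compounds go, how a non-ring group at this position, such as an amine or a carboxylic acid, would read remains open. So does whether a six-membered ring such as phenyl would follow the aromatic five-membered rings or cyclopent-1-en-1-yl.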